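Chlorophenyl in Place of a Donor-Bearing Ring

The source may hold more compounds than are shown below. What is called first, only, known or untested is meant among the compounds shown, and "the series" means these compounds.

Compound 1 `COc1ccc(C2Oc3ccccc3N(CCCCCN3C(C)CCCC3C)C2=O)cc1`: 2.3%
Compound 2 `CC1CCCC(C)N1CCCCCN1C(=O)C(c2cccc(C(=N)NO)c2)Oc2ccccc21`: 21%

Both compounds were tested in an assay on isolated protein for inhibition of serine protease 1 (Homo sapiens), tested at 100 uM; on this read-out lower numbers stand for less inhibition and higher numbers for more inhibition at the one concentration tested (going by the name of the read-out). For the measured compounds named here, of the two numbers, compound 2 stands highest, and its only neighbour is compound 1: a number 18.7 percentage points higher from compound 1 to compound 2 (beyond the scatter). The two differ in one place only, the group on the saturated ring carbon of the shared core.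

Compound 3 `CC1CCCC(C)N1CCCCCN1C(=O)C(c2ccc(Cl)cc2)Oc2ccccc21` alters that same place once more: a group of 7 heavy atoms (6 carbon, 1 chlorine; one six-membered aromatic ring of carbon only) in place of a group of 10 heavy atoms (7 carbon, 2 nitrogen, 1 oxygen; one six-membered aromatic ring of carbon only), on a saturated ring carbon. The group that leaves carries hydrogen-bond donors and acceptors, while the 4-chlorophenyl that enters carries none, so in this respect compound 3 resembles compound 1 more than it resembles compound 2.

Going by the values given here, the only measured step that bears on the change is a number 18.7 percentage points higher from compound 1 to compound 2 (beyond the scatter), which showed that exchanging a ring without donors for the donor-bearing group raised inhibition by a modest amount. Returning to a ring without donors is therefore expected to lower inhibition again, a number 15 percentage points lower from compound 2 to compound 3 (beyond the scatter), though one step is a thin basis for the guess. Compound 3 is expected to give about 6%, with a likely range from 0% to 18%.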

Compound 3, a percentage reported as inhibition, at one concentration (the size of the read-out at that concentration, not a potency): 46%
The estimate for compound 3 lay 40 percentage points below the measured number, and the stated range ends below it.
By their numbers in this assay, from the lowest: compound 1; then compound 2; then compound 3.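

In this assay, the 4-chlorophenyl on this saturated ring carbon gives the highest number of the three, a number 25 percentage points higher from compound 2 to compound 3 (beyond the scatter), so the hydrogen-bond donors of the group it replaces are not required for inhibition at this one concentration. The step of a number 43.7 percentage points higher from compound 1 to compound 3 (beyond the scatter), a chloro in place of a methoxy on the aromatic ring, is larger still and puts two rings without donors at opposite ends of the order, with donor-bearing compound 2 in the middle, so the presence or absence of donors does not by itself sort these compounds. Nothing available here explains why this single exchange on the ring matters so much.

Going by these compounds, it remains open whether a 4-fluorophenyl, a 4-bromophenyl or a plain phenyl would behave like the 4-chlorophenyl, and whether the chloro would give the same result at another carbon of the ring. All three numbers also come from one concentration and share one chain, so neither their potency nor the effect of the same exchange with a shorter chain can be read from them.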